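The source may report more compounds than this note shows. Statements on the series, on what has been measured and on what is new or still open speak of the compounds shown alone.

Three compounds measured in a functional assay for agonist activity at G protein-coupled receptor 88 (Homo sapiens), read by HTRF and cAMP accumulation (a higher number here means that more compound is needed for the effect, a lower number that less compound is needed), share one core. Compound 1 `CC(C)C[C@H](N)CN(C(=O)[C@@H]1C[C@H]1c1ccccc1)c1ccc(-c2ccccc2)cc1` gives 880 nM. Within the data shown here, compound 2 `O=C([C@@H]1C[C@H]1c1ccccc1)N(CCNCC1CCCCC1)c1ccc(-c2ccccc2)cc1` gives 6.6 nM, and the change a 130-fold lower number from compound 1 to compound 2 (2.12 log units; beyond the scatter) is the only step between measured compounds that differ in a single place. Compound 3 `CC[C@H](C)[C@H](N)CN(C(=O)[C@@H]1C[C@H]1c1cccc(C)c1)c1ccc(-c2ccccc2)cc1` gives 1200 nM, the highest of the three numbers; against compound 1 the gap lies within the scatter, against compound 2 far beyond it.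

Compound 4 `CC[C@H](C)[C@H](N)CN(C(=O)[C@@H]1C[C@H]1c1nccs1)c1ccc(-c2ccccc2)cc1` differs from compound 3 in one place: 1,3-thiazol-2-yl in place of 3-methylphenyl on a saturated ring carbon. Among the measured compounds shown here, the single measured step concerns the chain on the amide-type nitrogen, not the ring on the three-membered ring, so it does not bear on this change, and no step in this part of the molecule is available. With nothing to point either way, the expectation is a step of a 1.3-fold higher number from compound 3 to compound 4 (0.10 log units; within the scatter) that stays within the scatter. The estimate for compound 4 in this assay is therefore 1500 nM, with a range from 400 nM to 6000 nM.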

Compound 4, half-maximal effective concentration: 210 nM
Estimate against measurement, compound 4: 7.1-fold (0.85 log units) above, and the stated range ends above it.
By their numbers in this assay, from the lowest: compound 2; then compound 4; then compounds 1 and 3 (each within the scatter of the next).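

Among these compounds, the group on the three-membered ring turns out to matter: in this assay there is a 5.7-fold lower number from compound 3 to compound 4 (0.76 log units; beyond the scatter), the first step at this place, since the only earlier step concerned the chain on the amide-type nitrogen. The change replaces a six-membered aromatic ring of carbon only with a smaller five-membered aromatic ring with 2 hetero atoms, and it brings in hydrogen-bond acceptors where 3-methylphenyl has none. No measurement here separates these differences or explains why the number falls.

Going by these compounds, it remains open whether rings such as pyridin-2-yl or oxazol-2-yl, which carry nitrogen but no sulfur, would give a similar step. Also open, on these data alone, is whether 1,3-thiazol-2-yl would lower the number further on the chain of compound 2, which already gives 6.6 nM with a plain phenyl ring.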